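The compounds below may be only part of what the source reports. "The series", "measured", "known", "first", "only" and "open" are said of these compounds alone.

Compound 1 `C=CC(=O)Nc1cccc(-c2nc3ccccc3s2)c1` in an ADME assay on HEK293 cells (Homo sapiens) for inhibition, with a stated time of 72 h (on this read-out lower numbers stand for an effect already at smaller amounts and higher numbers for an effect only at larger amounts of compound), reaches only the limit > 25000 nM.
Compound 2 `C/C=C/C(=O)Nc1cccc(-c2nc3ccccc3s2)c1` in this assay likewise reaches only the limit > 25000 nM.
Compound 3 `C=C(C)C(=O)Nc1cccc(-c2nc3ccccc3s2)c1` in this assay also reaches only the limit > 25000 nM.

Compound 3 thus stands at the limit of the assay, where the two other measured compounds sit as well (the limit of > 25000 nM in this assay, at which 3 of the 3 values shown sit). Compound 4 `O=C(O)/C=C/C(=O)Nc1cccc(-c2nc3ccccc3s2)c1` differs from compound 3 by 2-carboxyethenyl in place of 1-methylethenyl on a carbonyl carbon. The measured steps that bear on this change are all of one kind: a step that the two limits leave unreadable from compound 1 to compound 2, a step that the two limits leave unreadable from compound 1 to compound 3 and a step that the two limits leave unreadable from compound 2 to compound 3, none of them readable in size because every value sits at the limit (the limit of > 25000 nM in this assay, at which 3 of the 3 values shown sit). Nothing measured points to a step away from that limit. Compound 4 is therefore expected to give 30000 nM, in a range from 10000 nM to 100000 nM. This amounts to an expected step that the limit leaves unreadable from compound 3 to compound 4.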

Compound 4, half-maximal effective concentration: > 25000 nM
Compound 4: a limit, no number; the forecaster's own chance of this, stated with the estimate: 85%; the middle value does not contradict the limit.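

No step from compound 1, compound 2 or compound 3 to compound 4 can be read, as all values are limits, not numbers: the limit of > 25000 nM in this assay, at which 4 of the 4 values shown sit.

The compounds shown leave open how far any of them lies beyond that limit in this assay.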